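Dichlorophenyl urea replacing nitrophenyl on the sulfonamide-linked scaffold

The compounds below may be only part of what the source reports. "The series", "measured", "known", "first", "only" and "open" are said of these compounds alone.

Of the compounds shown here, two have been measured in an assay for binding affinity to Apoptosis regulator Bcl-2 (Homo sapiens), read by fluorescence polarization, with stated times of 30 min and 20 min; on this read-out higher numbers stand for weaker inhibition and lower numbers for stronger inhibition. Compound 1 `O=C(NCCNS(=O)(=O)c1sccc1-c1ccccc1Oc1ccc(O)c(O)c1)Nc1cc(Cl)cc(Cl)c1` gives 4600 nM in this assay. Compound 2 `Cc1ccc(-c2ccsc2S(=O)(=O)NCCNC(=O)Nc2ccc([N+](=O)[O-])cc2)c(Oc2ccc(O)c(O)c2)c1` gives 13000 nM, the higher of the two numbers; the gap between compound 2 and compound 1 lies beyond the scatter of the method.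

Compound 3 `Cc1ccc(-c2ccsc2S(=O)(=O)NCCNC(=O)Nc2cc(Cl)cc(Cl)c2)c(Oc2ccc(O)c(O)c2)c1` has not yet been measured. It differs from compound 2 in one place: 3,5-dichlorophenyl in place of 4-nitrophenyl on an amide-type nitrogen. The entering 3,5-dichlorophenyl is the same group that compound 1 carries on its urea nitrogen.

For compound 3 a step downward from compound 2, of a size beyond the scatter, is expected in this assay, because compound 1 gives 4600 nM while carrying the same 3,5-dichlorophenyl on its urea nitrogen. The estimate for compound 3 is 5000 nM, within 2000 nM to 13000 nM, which corresponds to an expected step of a 2.6-fold lower number from compound 2 to compound 3 (0.41 log units; beyond the scatter).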

Compound 3, inhibition constant: 2900 nM
For compound 3 the middle estimate is 1.7-fold (0.24 log units) above the measured one; low and high end bracket the measured number.
By their numbers in this assay, from the lowest: compounds 3 and 1 (each within the scatter of the next); then compound 2.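

In this assay there is a 4.5-fold lower number from compound 2 to compound 3 (0.65 log units; beyond the scatter) when 3,5-dichlorophenyl replaces 4-nitrophenyl on an amide-type nitrogen, and this pair isolates that one change, which the two earlier compounds, differing in more than one place, could not do. Methyl in place of hydrogen on an aromatic carbon comes with a 1.6-fold lower number from compound 1 to compound 3 (0.20 log units; within the scatter) and so leaves no readable effect of that methyl while 3,5-dichlorophenyl sits on the urea nitrogen. No measurement here gives a reason for the step between the two aryl groups.

Going by these compounds, whether a plain phenyl or a cyclohexyl on that nitrogen would fall nearer compound 2 or compound 3 remains open, and with it whether the step follows the entry of the chlorines or the departure of the nitro group. Also open, on these data alone, is whether the methyl stays without a readable effect when 4-nitrophenyl is the group on the urea nitrogen.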